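The source may report more compounds than this note shows. Statements on the series, on what has been measured and on what is new or still open speak of the compounds shown alone.

Compound 1, `CCc1ccccc1-c1cccc(COc2ccc([C@H](CC(=O)O)c3nccn3C)cc2)c1`: in an assay on CHO cells for agonist activity at Free fatty acid receptor 1 (Homo sapiens), read by luminescence, with a stated time of 20 s, in the presence of a further agent that is not named here (on this read-out higher numbers stand for an effect only at larger amounts of compound and lower numbers for an effect already at smaller amounts), compound 1 gives 65000 nM.
Compound 2, `Cn1ccnc1[C@@H](CC(=O)O)c1ccc(OCc2cccc(-c3ccccc3S(C)(=O)=O)c2)cc1`: for compound 2 this assay gives "not determined" (no result reported).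
Compound 3, `Cc1cc(Cl)ccc1-c1cccc(COc2ccc([C@H](CC(=O)O)c3nccn3C)cc2)c1C`: in this assay compound 3 gives 23000 nM.

Compound 3 holds the lowest of the two numbers shown; compound 1 lies at a higher number, beyond the scatter, and compound 2 contributes no number. Compound 4, `Cc1cc(Cl)ccc1-c1cccc(COc2ccc([C@H](CC(=O)O)c3nccn3C)cc2)c1`, differs from compound 3 by hydrogen in place of methyl on an aromatic carbon. Among the compounds with values here, no measured pair of this kind is available to size the step. The change removes one carbon from compound 3, and the account expects a small step, most likely within the scatter or slightly toward a higher number, a 1.3-fold higher number from compound 3 to compound 4 (0.12 log units; within the scatter). Compound 4 is therefore estimated at 30000 nM, expected within 10000 nM to 90000 nM.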

Compound 4, half-maximal effective concentration: 10000 nM
Estimate against measurement, compound 4: 3.0-fold (0.48 log units) above, and the stated range covers the measured number.
By their numbers in this assay, from the lowest: compound 4; then compound 3; then compound 1.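

In this assay, replacing the methyl with hydrogen on the aromatic carbon ortho to a 4-chloro-2-methylphenyl group gives a 2.3-fold lower number from compound 3 to compound 4 (0.36 log units; beyond the scatter), so at this position the added methyl of compound 3 does not lower the number. Exchanging 2-ethylphenyl for 4-chloro-2-methylphenyl gives a 6.5-fold lower number from compound 1 to compound 4 (0.81 log units; beyond the scatter), also beyond the scatter. Nothing available explains either step.

The compounds shown leave open how a fluorine atom or a methoxy group on this carbon would compare with hydrogen and methyl. They also leave open whether the methyl-to-hydrogen step holds with 2-ethylphenyl as the neighbouring group.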